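The source may report more compounds than this note shows. Statements on the series, on what has been measured and on what is new or still open speak of the compounds shown alone.

Compound 3, `O=C(Nc1cccc(F)c1)c1cc(=O)[nH]c2cc(F)ccc12`, was tested in a functional assay on KYSE-70 cells for antiproliferative activity against KYSE-70 cell line (Homo sapiens), read by MTT assay, with a stated time of 72 h; a lower number here means a stronger inhibitor, a higher number a weaker inhibitor. For compound 3 the result is only a limit, > 20000 nM, not a number. Two other compounds were run in this assay. Compound 1, `O=C(c1ccnc2cc(Br)ccc12)N1CCCCC1`, also ends at a limit, and compound 1 gives > 20000 nM. Compound 2, `O=C(Nc1ccccn1)c1cc(=O)[nH]c2cc(Br)ccc12`, gives a number, 11000 nM. So compound 3 stands at the weak end of what is shown, on the limit described by the limit of > 20000 nM in this assay, at which 2 of the 3 values shown sit, with only compound 2 giving a measurable number.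

Compound 4, `C#Cc1ccc2c(C(=O)Nc3cccc(F)c3)cc(=O)[nH]c2c1`, differs from compound 3 in one place: ethynyl in place of fluoro on an aromatic carbon. No step between two measured compounds is shown, so nothing measured tells how large this change might be. Because compound 3 sits at a limit > 20000 nM, any gain for compound 4 can only be guessed at, and it is expected to be modest, possibly not beyond the scatter, as the step of an at least 2.2-fold lower number from compound 3 to compound 4 (0.34 log units; beyond the scatter) expresses. Compound 4 is estimated at 9000 nM, with a range from 1500 nM to 20000 nM.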

Compound 4, half-maximal inhibitory concentration: 9500 nM
For compound 4 the middle estimate is 1.1-fold (0.02 log units) below the measured one; measured number inside the range.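

In this assay, among the compounds shown here, ethynyl in place of fluoro on this aromatic carbon gives an at least 2.1-fold lower number from compound 3 to compound 4 (0.32 log units; beyond the scatter), the first step between two compounds that differ in one place. For the compounds shown here, it shows that a single change at this carbon of the shared core can move a compound off the limit and onto a measurable number, which the earlier compounds, taken alone, could not show. The full size of the step cannot be read, because compound 3 has only a limit and not a number: the limit of > 20000 nM in this assay, at which 2 of the 4 values shown sit.

From the compounds shown here alone, whether a nitrile, an amine or a longer chain on this carbon would lower the number further remains open. Also open is how much of the step comes from the triple bond itself, since a plain hydrogen at this place is not among the compounds shown.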